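Meta-substituted benzohydrazones of a chlorinated tricyclic aldehyde

The compounds below may be only part of what the source reports. "The series", "measured", "known", "first", "only" and "open" are said of these compounds alone.

Measured compounds:
compound 1 `O=C(N/N=C/C1=C(Cl)c2ccccc2CCC1)c1ccccc1` — > 100000 nM
compound 2 `O=C(N/N=C/C1=C(Cl)c2ccccc2CCC1)c1cccc(Cl)c1` — 19200 nM
compound 3 `O=C(N/N=C/C1=C(Cl)c2ccccc2CCC1)c1cccc(I)c1` — 6300 nM

Three compounds sharing one core differ only in the substituent on the benzoyl ring. In a functional assay on HeLa cells (Homo sapiens) for inhibition, read by sulforhodamine B assay, with a stated time of 48 h (on this read-out higher numbers stand for weaker inhibition of growth and lower numbers for stronger inhibition of growth), compound 1 reaches only the limit of > 100000 nM in this assay, at which 1 of the 3 values shown sits, and gives no number. Compound 2 gives 19200 nM, compound 3 gives 6300 nM. Compound 3 thus holds the lowest number of the two that were read, with compound 2 nearest; the step from the unsubstituted parent is an at least 5.2-fold lower number from compound 1 to compound 2 (0.71 log units; beyond the scatter) and an at least 15-fold lower number from compound 1 to compound 3 (1.20 log units; beyond the scatter), and between the two halogens a 3.0-fold lower number from compound 2 to compound 3 (0.48 log units; beyond the scatter).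

Compound 4 `O=C(N/N=C/C1=C(Cl)c2ccccc2CCC1)c1cccc(C(F)(F)F)c1` carries trifluoromethyl in place of iodo on an aromatic carbon. Going by the values given here, no measured step involves a trifluoromethyl group, so the expectation rests on the substituted-versus-unsubstituted steps and on the halogen exchange. Both substituted compounds sit well below the limit of compound 1, and the exchange of chloro for iodo was modest in size. A trifluoromethyl group is expected to land in the span between compound 2 and compound 3, with a slight loss relative to compound 3. The step of a 1.6-fold higher number from compound 3 to compound 4 (0.20 log units; within the scatter) is the estimated size of that loss. Compound 4 is therefore estimated at 10000 nM in this assay, within 4000 nM to 30000 nM.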

Compound 4, concentration for 50% growth inhibition: 16300 nM
Compound 4: middle estimate off by 1.6-fold (0.21 log units), on the low side, and the stated range covers the measured number.
By their numbers in this assay, from the lowest: compound 3; then compounds 4 and 2 (each within the scatter of the next). At a limit, above all of these: compound 1.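

In this assay, trifluoromethyl on this aromatic carbon also gives a readable number well clear of the unsubstituted parent (an at least 6.1-fold lower number from compound 1 to compound 4 (0.78 log units; beyond the scatter)), so the gain over compound 1 is not confined to the halogens among the groups shown. Compound 1 stands only at a limit, so that step has a floor and no exact size: the limit of > 100000 nM in this assay, at which 1 of the 4 values shown sits. Exchange of iodo for trifluoromethyl is not neutral (a 2.6-fold higher number from compound 3 to compound 4 (0.41 log units; beyond the scatter)), whereas exchange of chloro for trifluoromethyl stays inside the scatter (a 1.2-fold lower number from compound 2 to compound 4 (0.07 log units; within the scatter)), so compounds 2 and 4 cannot be told apart here and only the iodo compound 3 stands clear of both.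

Open, as far as these compounds go, is whether any group on this carbon lowers the number or only some do: an amine, a carboxylic acid, a methoxy group or a longer alkyl chain would test that. Also open, from the compounds shown here alone, is how chloro, iodo and trifluoromethyl behave on the other carbons of the benzoyl ring, and whether the edge of compound 3 survives changes to the shared core.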